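The compounds below may be only part of what the source reports. "The series", "measured", "known", "first", "only" and "open" are said of these compounds alone.

The measured compounds:

Compound 1, `Nc1ccccc1NC(=O)/C=C/c1ccc(Cn2cnc3c(NC4CCCCC4)nc(Cl)nc32)cc1`, gives 18.7% in a functional assay on HCT-116 cells (Homo sapiens) for antiproliferative activity, read by CCK-8 assay, with a stated time of 72 h, tested at 8 uM; on this read-out lower numbers stand for a weaker effect and higher numbers for a stronger effect at the one concentration tested.
Compound 2, `Nc1ccccc1NC(=O)c1ccc(CNc2nc(Cl)nc3c2ncn3Cc2ccccc2)cc1`, gives 11.5% in this assay.
Compound 3, `CC(C)n1cnc2c(Nc3ccccc3)nc(NCOCc3ccc(C(=O)Nc4ccccc4N)cc3)nc21`, gives 18.8% in this assay.

All three numbers in this assay lie close together. Compound 2 stands within the usual scatter of both compound 1 and compound 3, so the three measured compounds cannot be told apart on these numbers, and none of them can be called the stronger or weaker one.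

Compound 4, `CCCn1cnc2c(NCc3ccc(C(=O)Nc4ccccc4N)cc3)nc(Cl)nc21`, has not yet been measured. It differs from compound 2 in one place: ethyl in place of phenyl on a saturated chain carbon bound to an aromatic nitrogen. For the measured compounds named here, no pair of measured compounds differs in only one place, so this change has no measured counterpart among the three compounds already tested. Going by the values given here, the only guide is that the three measured compounds, with their different groups on the shared core, all gave numbers within the scatter of one another in this assay.

On that basis, the step from compound 2 to compound 4 is expected to be a number 2.5 percentage points higher from compound 2 to compound 4 (within the scatter), that is, no change beyond the scatter in either direction. Compound 4 is therefore estimated to give 14%, with a range from 4% to 27%.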

Compound 4, a percentage reported as inhibition, at one concentration (the size of the read-out at that concentration, not a potency): 29.6%
Compound 4: the middle estimate sits 15.6 percentage points below what was measured; the whole stated range lies below it.
By their numbers in this assay, from the lowest: compounds 2, 1 and 3 (each within the scatter of the next); then compound 4.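

In this assay, the change from phenyl to ethyl on a saturated chain carbon bound to an aromatic nitrogen provides the only comparison among these compounds that differ in one place, and it gives a number 18.1 percentage points higher from compound 2 to compound 4 (beyond the scatter), so the number at this position responds to the group it carries. Read one bond further out as benzyl to propyl, the change replaces a six-membered aromatic ring of carbon only with a plain chain while the rest of the structure stays the same, which shows that this ring is not needed for the effect at the one concentration tested. The step is modest and rests on a single pair, and nothing measured here bears on why the number rises.

From the compounds shown here alone, it remains open whether the rise follows from losing the ring or from the shorter group, since a longer chain such as butyl, or a chain ending in an amine, would be needed to separate the two. Going by these compounds, it is also open whether the same change would read alike with the other groups carried by compound 1 and compound 3.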